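This account rests on a few compounds, and the source may have more. Where it says the series, first, only, none or still open, it means among the compounds named here.

Measured in a functional assay on MCF7 cells (Homo sapiens) for cytotoxicity, read by MTT assay, with a stated time of 72 h; a higher number here means a weaker inhibitor, a lower number a stronger inhibitor:

Compound 1 `Cc1nnc(SCc2cc(=O)c3cc(Cl)ccc3o2)o1` gives > 25000 nM, a limit of the assay.
Compound 2 `Nc1nnc(SCc2cc(=O)c3cc(Cl)ccc3o2)s1` gives > 25000 nM, a limit of the assay.
Compound 3 `Cc1nnc(SCc2cc(=O)c3cc(Cl)ccc3o2)s1` gives > 25000 nM, a limit of the assay.

Compound 1 stands nowhere on a scale: in this assay its value is only a limit, and the same holds for the other two, as the limit of > 25000 nM in this assay, at which 3 of the 3 values shown sit, records. The three steps among them, a step that the two limits leave unreadable from compound 1 to compound 2, a step that the two limits leave unreadable from compound 1 to compound 3 and a step that the two limits leave unreadable from compound 2 to compound 3, all concern the ring attached through the sulfur and remain unreadable, since both ends of each sit at the limit.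

Compound 4 `Cc1ccc2oc(CSc3nnc(C)o3)cc(=O)c2c1` differs from compound 1 at the other end of the shared core: methyl in place of chloro on an aromatic carbon. Among the measured compounds shown here, none of the measured steps touches this position, so nothing measured bears on it directly; the only guidance is that every variation of the core seen so far has left the value at the limit. Compound 4 is therefore expected to stay at the limit as well, with an estimated value of 30000 nM, in a range from 8000 nM to 100000 nM. The step expected is a step that the limit leaves unreadable from compound 1 to compound 4, which cannot be read as a change beyond the scatter.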

Compound 4, half-maximal inhibitory concentration: > 25000 nM
Compound 4: no number, only a limit; the forecaster's own chance of this, stated with the estimate: 85%; the middle value lies beyond the limit too.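

Compound 4 gives > 25000 nM in this assay, which is a limit of the assay, so its step from compound 1 cannot be read, with both compounds at the same limit: the limit of > 25000 nM in this assay, at which 4 of the 4 values shown sit.

The compounds shown leave open whether any variation of the shared core yields a number rather than a limit in this assay, and how the four compare with one another.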